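The source may report more compounds than this note shows. Statements on the series, on what has been measured and on what is new or still open speak of the compounds shown alone.

Measured compounds in a functional assay on A549 cells (Homo sapiens) for cytotoxicity, read by MTT assay, with a stated time of 72 h; a lower number here means a stronger inhibitor, a higher number a weaker inhibitor:
Compound 1 `COc1cc(/C=C/C(=O)Nc2cc3c(Nc4ccc(F)c(Cl)c4)ncnc3cc2OC)cc(OC)c1` gives "not active" (no number reported).
Compound 2 `COc1cc(/C=C/C(=O)Nc2cc3c(Nc4ccc(F)c(Cl)c4)ncnc3cc2O[C@H]2CCOC2)cc(OC)c1` gives 10800 nM.
Compound 3 `COc1cc2ncnc(Nc3ccc(F)c(Cl)c3)c2cc1NC(=O)/C=C/c1ccc(F)cc1Cl` gives "not active" (no number reported).

Among these three, compound 2 is the only one with a reported number in this assay; compound 1 and compound 3 carry no single number there, and the value of compound 2 itself lies in the weak range. Compound 4 `O=C(/C=C/c1ccccc1[N+](=O)[O-])Nc1cc2c(Nc3ccc(F)c(Cl)c3)ncnc2cc1O[C@H]1CCOC1` has not yet been measured. It differs from compound 2 in one place: 2-nitrophenyl in place of 3,5-dimethoxyphenyl on a double-bonded chain carbon bound to a double-bonded chain carbon. Within the data shown here, no pair of the measured compounds differs in a single place, so there is no measured step to lean on for this change. The expectation is therefore that the change does not move compound 4 beyond the usual scatter in either direction, with a real chance that, like compound 1 and compound 3, it yields no number at all. The step from compound 2 to compound 4 is expected to be a 1.1-fold higher number from compound 2 to compound 4 (0.05 log units; within the scatter). Compound 4 is estimated at 12000 nM, with a range from 4000 nM to 40000 nM.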

Compound 4, half-maximal inhibitory concentration: 8820 nM
Beside the measured number, compound 4's estimate is 1.4-fold (0.13 log units) above it, within the range that was stated.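

Among these compounds, the exchange of 3,5-dimethoxyphenyl for 2-nitrophenyl on a double-bonded chain carbon bound to a double-bonded chain carbon yields a 1.2-fold lower number from compound 2 to compound 4 (0.09 log units; within the scatter) in this assay and provides the first readable step at this position. This position therefore accepts two different substituted phenyl groups, one with two methoxy groups and one with a nitro group, without a difference beyond the scatter, and both numbers remain in the weak range. Nothing measured here accounts for this similarity.

As far as these compounds go, whether an unsubstituted phenyl, a primary amine or a carboxylic acid at this place would give a number beyond the scatter remains open. Compound 1 and compound 3 carry no number, so this single step is all that can be read at this position.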